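This account rests on a few compounds, and the source may have more. Where it says the series, first, only, none or still open, it means among the compounds named here.

Three compounds share one core and differ only in a single group on a six-membered aromatic ring of carbon only. Compound 1 `Cc1ccc(NS(=O)(=O)c2cccc(CCCCCCNC(=O)/C=C/c3cccnc3)c2)cc1` carries a methyl group there, and in an assay on isolated protein for inhibition of Nicotinamide phosphoribosyltransferase (Homo sapiens), read by WST assay, with stated times of 60 min, 5 min and 30 min, in the presence of a further agent that is not named here (on this read-out higher numbers stand for weaker inhibition and lower numbers for stronger inhibition), compound 1 gives 9.78 nM. Compound 2 `CC(C)(C)c1ccc(NS(=O)(=O)c2cccc(CCCCCCNC(=O)/C=C/c3cccnc3)c2)cc1` carries a tert-butyl group, and in this assay compound 2 gives 9.47 nM. Compound 3 `O=C(/C=C/c1cccnc1)NCCCCCCc1cccc(S(=O)(=O)Nc2ccc(F)cc2)c1` carries a fluoro group, and in this assay compound 3 gives 9.2 nM, the lowest of the three numbers, though every gap is within the scatter: a 1.1-fold lower number from compound 1 to compound 3 (0.03 log units; within the scatter), a 1.0-fold lower number from compound 2 to compound 3 (0.01 log units; within the scatter), and between the first two a 1.0-fold lower number from compound 1 to compound 2 (0.01 log units; within the scatter). Compound 4 `O=C(/C=C/c1cccnc1)NCCCCCCc1cccc(S(=O)(=O)Nc2ccc(F)c(Cl)c2)c1` differs from compound 3 by chloro in place of hydrogen on an aromatic carbon. All three measured steps swapped a group on this same ring, and none of them moved the number beyond the scatter, so a further change on this ring is expected to behave alike; the estimated step is a 1.0-fold lower number from compound 3 to compound 4 (0.01 log units; within the scatter). Compound 4 is therefore expected to give 9 nM, within a range of 4.5 nM to 18 nM.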

Compound 4, half-maximal inhibitory concentration: 9.7 nM
Compound 4: the middle estimate sits 1.1-fold (0.03 log units) below what was measured; the range from low to high includes it.
By their numbers in this assay, from the lowest: compounds 3, 2, 4 and 1 (each within the scatter of the next).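

In this assay, among the compounds shown here, the ring carries a second group for the first time: chloro enters ortho to a fluoro group and meta to a large group, a place that holds only hydrogen in the earlier compounds, and the result is a 1.1-fold higher number from compound 3 to compound 4 (0.02 log units; within the scatter). Set against the other two compounds, the whole 3-chloro-4-fluorophenyl group also stays within the scatter, with a 1.0-fold higher number from compound 2 to compound 4 (0.01 log units; within the scatter) and a 1.0-fold lower number from compound 1 to compound 4 (0.00 log units; within the scatter). Nothing measured here accounts for this lack of movement.

The compounds shown leave open whether any group on this ring can move the number beyond the scatter, for instance an amine or a carboxylic acid in place of the chloro. They also leave open whether a longer chain in the shared core would change the number more than these ring changes did.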